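A Hydroxy Group Added to Compound 1

The source may hold more compounds than are shown below. What is called first, only, known or untested is meant among the compounds shown, and "the series" means these compounds.

Measured in a functional assay on HCC116 cells (Homo sapiens) for inhibition; a higher number here means a weaker inhibitor of growth, a lower number a stronger inhibitor of growth:
Compound 1 `COc1ccc(-n2cnnc2-c2cc(OC)c(OC)c(OC)c2)cc1`: 3020 nM
Compound 2 `COc1cc(-c2nncn2-c2ccc(N(C)C)cc2)cc(OC)c1OC`: 60.3 nM

Of these two measured compounds, compound 1 has the higher number and is therefore the weaker inhibitor of growth. The next compound, compound 3 `COc1ccc(-n2cnnc2-c2cc(OC)c(OC)c(OC)c2)cc1O`, has not yet been measured. It differs from compound 1 by one change: hydroxy in place of hydrogen on an aromatic carbon. In words, hydroxy takes the place of hydrogen on an aromatic carbon.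

For the measured compounds named here, only one measured step bears on this, and only indirectly. Dimethylamino in place of methoxy on an aromatic carbon gave a 50-fold lower number from compound 1 to compound 2 (1.70 log units; beyond the scatter). That step shows that a single substitution on the core of compound 1 can move the number a long way, but it involves a different group. Going by the values given here, no measured compound carries hydroxy, so neither the direction nor the size is settled by the data.

A lower number is still expected, with a step smaller than that one. The expected change in this assay is a 12-fold lower number from compound 1 to compound 3 (1.08 log units; beyond the scatter). Compound 3 is estimated at 250 nM, within an expected range of 30 nM to 2000 nM.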

Compound 3, concentration for 50% growth inhibition: 398 nM
Beside the measured number, compound 3's estimate is 1.6-fold (0.20 log units) below it, and the stated range covers the measured number.
By their numbers in this assay, from the lowest: compound 2; then compound 3; then compound 1.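

In this assay, the step of a 7.6-fold lower number from compound 1 to compound 3 (0.88 log units; beyond the scatter) shows that this aromatic carbon, ortho to a methoxy group and meta to a large group, is not indifferent to what it carries. The earlier compounds had shown only one group exchanged for another, whereas here a lower number comes from hydroxy taking the place of a mere hydrogen, with every methoxy group of compound 1 left in place. The shared core therefore now has two single changes that lower the number, dimethylamino in place of methoxy and hydroxy in place of hydrogen, although nothing shown here accounts for the effect of the latter.

The compounds shown leave open whether an amine, a fluorine atom or a methoxy group on this same aromatic carbon would lower the number as hydroxy does, or would fail to lower it at all. They also leave open whether hydroxy and dimethylamino, placed together in one compound, would lower the number further than either change does alone.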